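Hydrogen in place of fluoro on compound 2

A few compounds are considered here, and "the series" means these few. Any claim that something is new, unique, unknown or untested is made for them only; others in the source may bear on it.

Compound 1 `O=[N+]([O-])c1ccc(C2=NOC(c3ccc(N4CCCCC4)cc3)C2)o1`: 103 nm/s
Compound 2 `O=C1COCCN1c1ccc(C2CC(c3ccc([N+](=O)[O-])o3)=NO2)cc1F`: 424 nm/s

Both compounds were measured in an ADME assay on Caco-2 cells (Homo sapiens) for permeability, read by HPLC, with a stated time of 2 h; a lower number here means that the compound crosses the layer more slowly, a higher number that the compound crosses the layer faster. Compound 2 holds the higher of the two numbers, at 424 nm/s, and its gap to compound 1 lies beyond the usual scatter of the measurement. The unmeasured compound 3 `O=C1COCCN1c1ccc(C2CC(c3ccc([N+](=O)[O-])o3)=NO2)cc1` differs from compound 2 in one place: hydrogen in place of fluoro on an aromatic carbon. In words, hydrogen stands in place of fluoro on an aromatic carbon. Among the measured compounds shown here, no pair of measured compounds shows this change, so the data give no direct guide to its size. A swap of one atom on an otherwise identical structure is expected to stay within the scatter, with no firm direction. The expected result is a 1.1-fold lower number from compound 2 to compound 3 (0.05 log units; within the scatter). Compound 3 is estimated at 380 nm/s, with an expected range of 190 nm/s to 750 nm/s.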

Compound 3, apparent permeability: 565 nm/s
For compound 3 the middle estimate is 1.5-fold (0.17 log units) below the measured one, and the stated range covers the measured number.
By their numbers in this assay, from the lowest: compound 1; then compounds 2 and 3 (each within the scatter of the next).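

In this assay, hydrogen in place of fluoro on the aromatic carbon ortho to the 3-oxomorpholin-4-yl group gives a 1.3-fold higher number from compound 2 to compound 3 (0.12 log units; within the scatter) and so stays within the usual scatter of repeated measurements at this position. Compound 3 also provides a comparison of two compounds that differ in one place and lie beyond that scatter: 3-oxomorpholin-4-yl in place of piperidin-1-yl gives a 5.5-fold higher number from compound 1 to compound 3 (0.74 log units; beyond the scatter) on an otherwise shared structure. No measurement shown here accounts for either step.

From the compounds shown here alone, what another group on this aromatic carbon, such as chloro, methoxy or an amine, would do to the number remains open. Also open, going by these compounds, is whether fluoro at this position would give a similar result with piperidin-1-yl in place of 3-oxomorpholin-4-yl.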